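The compounds below may be only part of what the source reports. "The series", "measured", "known", "first", "only" and "open" are said of these compounds alone.

Series notes. Compound 1 `CN(C)c1nccc2c1ncn2C1O[C@H](CO)[C@@H](O)[C@H]1O` carries a dimethylamino group on the shared core. Going by the values given here, in a functional assay (Homo sapiens) for inhibition of Nucleic Acid, tested at 100 uM (on this read-out lower numbers stand for less inhibition and higher numbers for more inhibition at the one concentration tested (going by the name of the read-out)), compound 1 gives 0%, the lowest of the three numbers so far. Compound 2 `[N-]=[N+]=Nc1[nH]ccc2ncnc1-2` gives 20% in this assay, the nearest number to that of compound 1, yet higher by more than the usual scatter. Compound 3 `CSc1nccc2c1ncn2[C@H]1C[C@H](O)[C@@H](CO)O1` gives 36% in this assay, the furthest from compound 1 and also beyond the scatter. No pair among these three differs in a single place, so no step between measured compounds can be drawn.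

Compound 4 `CCCCCCNc1nccc2c1ncn2C1O[C@H](CO)[C@@H](O)[C@H]1O` is the next entry. Relative to compound 1 the change is hexylamino in place of dimethylamino on an aromatic carbon. Among the compounds with values here, nothing measured so far carries a hexylamino group, so the step can only be judged loosely against the value of compound 1 in this assay, 0%. A small upward step is expected, possibly none beyond the scatter: a number 15 percentage points higher from compound 1 to compound 4 (beyond the scatter). Compound 4 is estimated to give 15% in this assay, with an expected range from 0% to 45%.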

Compound 4, a percentage reported as inhibition, at one concentration (the size of the read-out at that concentration, not a potency): 8%
For compound 4 the middle estimate is 7 percentage points above the measured one; the range from low to high includes it.
By their numbers in this assay, from the lowest: compounds 1 and 4 (each within the scatter of the next); then compound 2; then compound 3.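

In this assay, hexylamino in place of dimethylamino on an aromatic carbon next to the ring nitrogen gives a number 8 percentage points higher from compound 1 to compound 4 (within the scatter). Going by these compounds alone, at this position, then, 7 heavy atoms instead of 3 and a hydrogen-bond donor where there was none come with no change that can be told from the scatter, and this is the first step that can be read at all. Nothing at hand offers a reason for this result.

Going by these compounds, whether an unsubstituted amine, a shorter chain such as ethylamino or a longer chain such as decylamino at this carbon would move the number beyond the scatter stays open. Also open, on these data alone, is whether a carboxylic acid at the end of the hexyl chain would change the reading.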